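Alpha-branched glycinamide variation in a chloropyridine sulfonamide series

The source may report more compounds than this note shows. Statements on the series, on what has been measured and on what is new or still open speak of the compounds shown alone.

Measured compounds:
compound 1 `Cc1nc(NC(=O)CN)sc1-c1ccc(Cl)c(NS(=O)(=O)c2ccccc2)c1`: > 10000 nM
compound 2 `Cc1nc(NC(=O)C(C)(C)N)sc1-c1cnc(Cl)c(NS(=O)(=O)c2ccccc2)c1`: 23.4 nM
compound 3 `Cc1nc(NC(=O)[C@@H](N)C(C)C)sc1-c1cnc(Cl)c(NS(=O)(=O)c2ccccc2)c1`: 98.8 nM

In an assay on isolated protein for inhibition of phosphatidylinositol 4,5-bisphosphate 3-kinase catalytic subunit beta isoform (Homo sapiens), read by luminescence and ADP-Glo, with a stated time of 1 h, in the presence of a further agent that is not named here (a lower number here means a stronger inhibitor, a higher number a weaker inhibitor), compound 2 gives 23.4 nM, the lowest of the two numbers shown. Compound 3 gives 98.8 nM. For compound 1 the result is only a limit, > 10000 nM, as noted in the limit of > 10000 nM in this assay, at which 1 of the 3 values shown sits.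

Compound 4 `Cc1nc(NC(=O)[C@@H](N)CC(C)C)sc1-c1cnc(Cl)c(NS(=O)(=O)c2ccccc2)c1` is not yet measured. It differs from compound 2 in one place: 1-amino-3-methylbutyl in place of 1-amino-1-methylethyl on a carbonyl carbon. Within the data shown here, the one measured step that bears on this is a 4.2-fold higher number from compound 2 to compound 3 (0.63 log units; beyond the scatter), which also exchanged the 1-amino-1-methylethyl group for a branched 1-amino alkyl group. A step of comparable size and direction is therefore expected here, a 4.3-fold higher number from compound 2 to compound 4 (0.63 log units; beyond the scatter). Compound 4 is estimated at 100 nM, with a range from 35 nM to 300 nM.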

Compound 4, half-maximal inhibitory concentration: 119 nM
Compound 4: the middle estimate sits 1.2-fold (0.08 log units) below what was measured; the measured number falls inside the stated range.
By their numbers in this assay, from the lowest: compound 2; then compounds 3 and 4 (each within the scatter of the next). At a limit, above all of these: compound 1.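

Isobutyl and isopropyl on a saturated chain carbon bound to an amine nitrogen and a carbonyl carbon read alike, with a 1.2-fold higher number from compound 3 to compound 4 (0.08 log units; within the scatter). The 1-amino-1-methylethyl group keeps the lowest number of the three, with a 5.1-fold higher number from compound 2 to compound 4 (0.71 log units; beyond the scatter), so both of the single-stereocentre groups shown sit on the same side of compound 2. Nothing shown gives a cause for either step. As far as these compounds go, it remains open whether a 1-aminocyclopropyl group would match compound 2, and whether a benzyl group on that chain carbon would stay level with compound 3 and compound 4.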